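From Methoxy to Hydroxy on the Core of Compound 2

The compounds below may be only part of what the source reports. "The series", "measured", "known", "first", "only" and "open" are said of these compounds alone.

Of the compounds shown here, three have so far been measured in a functional assay on MCF7 cells (Homo sapiens) for cytotoxicity, read by MTT assay, with a stated time of 72 h; on this read-out lower numbers stand for stronger inhibition and higher numbers for weaker inhibition. Compound 1 `COc1ccc(/C=C/c2cc(C)n[nH]2)cc1OC` gives 12600 nM, compound 2 `COc1ccc(/C=C/c2cc(C)n[nH]2)cc1` gives 9700 nM, and compound 3 `CC(=O)/C=C(O)/C=C/c1ccc(O)c(O)c1` gives 7900 nM. Compound 2 thus stands second highest of the three numbers, with the other two values within the scatter on either side of it. Within the data shown here, the only single-point step measured, a 1.3-fold lower number from compound 1 to compound 2 (0.11 log units; within the scatter), stays within the scatter.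

Compound 4 `Cc1cc(/C=C/c2ccc(O)cc2)[nH]n1` differs from compound 2 in one place: hydrogen in place of methyl on an oxygen on an aromatic ring. Among the measured compounds shown here, no measured step tests this exact change. For the measured compounds named here, the step from compound 1 to compound 2 removes a whole methoxy rather than only its methyl, and compound 3 carries hydroxy groups on a different core, so it forms no single-point pair with compound 2. With nothing beyond the scatter seen so far, the step from compound 2 to compound 4 is expected to be about a 1.1-fold lower number from compound 2 to compound 4 (0.06 log units; within the scatter), that is, no change beyond the scatter. Compound 4 is therefore estimated at 8500 nM, with a likely range from 3000 nM to 25000 nM.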

Compound 4, half-maximal inhibitory concentration: 48100 nM
The estimate for compound 4 lay 5.7-fold (0.75 log units) below the measured number; the measured number lies above the stated range.
By their numbers in this assay, from the lowest: compounds 3, 2 and 1 (each within the scatter of the next); then compound 4.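

Swapping methoxy for hydroxy on the aromatic ring gives a 5.0-fold higher number from compound 2 to compound 4 (0.70 log units; beyond the scatter) in this assay, so losing a single methyl from that oxygen weakens inhibition on this read-out. Among these compounds, the earlier step, a 1.3-fold lower number from compound 1 to compound 2 (0.11 log units; within the scatter), took away a whole methoxy, which makes this the first single change on the shared core seen to move the number beyond the scatter, and it shows that this oxygen's substituent can matter even though removing a methoxy did not. Nothing available here accounts for the size of this step.

On these data alone, it remains open whether a longer chain such as ethyl on this oxygen would keep the number near that of compound 2 or push it higher. As far as these compounds go, it is equally open whether an amine in place of the hydroxy would behave like the hydroxy of compound 4.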